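A few compounds are considered here, and "the series" means these few. Any claim that something is new, unique, unknown or untested is made for them only; others in the source may bear on it.

Measured so far in a functional assay on CEM-DNR cells (Homo sapiens), read by MTT assay, with a stated time of 3 days; on this read-out higher numbers stand for weaker inhibition and lower numbers for stronger inhibition:

Compound 1 `Cc1ncnc2[nH]cc(Sc3cccs3)c12` gives > 50000 nM, a limit of the assay and not a number.
Compound 2 `COc1ncnc2[nH]cc(Sc3cccs3)c12` gives > 50000 nM, again a limit of the assay.
Compound 3 `CN(C)c1ncnc2[nH]cc(Sc3cccs3)c12` gives 35300 nM.

Compound 2 stands at the assay limit, as does compound 1, so two of the three values sit at the limit of > 50000 nM in this assay, at which 2 of the 3 values shown sit. The step that the two limits leave unreadable from compound 1 to compound 2 is therefore unreadable. The step of an at least 1.4-fold lower number from compound 2 to compound 3 (0.15 log units; that floor lies within the scatter) is known only as a floor, and that floor lies within the scatter; the same holds for an at least 1.4-fold lower number from compound 1 to compound 3 (0.15 log units; that floor lies within the scatter). Nothing in this assay separates the three compounds beyond the scatter; all of them sit at or near the limit.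

Compound 4 `c1coc(-c2ncnc3[nH]cc(Sc4cccs4)c23)c1` is not yet measured. (furan-2-yl in place of methoxy on an aromatic carbon). Within the data shown here, no measured step places a ring at this position, so the only bearing comes from the two small substituent swaps at the same carbon, both of which gave steps within the scatter. On that basis no step beyond the scatter is expected in this assay, and a limit rather than a number is a real possibility. Compound 4 is expected near 40000 nM, in the range 15000 nM to 100000 nM. That estimate means an expected step of an at least 1.2-fold lower number from compound 2 to compound 4 (0.09 log units; that floor lies within the scatter), within the scatter.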

Compound 4, half-maximal inhibitory concentration: 20800 nM
Compound 4: the middle estimate sits 1.9-fold (0.28 log units) above what was measured; low and high end bracket the measured number.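

In this assay, among these compounds, furan-2-yl on this aromatic carbon gives the first steps that are readable beyond the scatter: an at least 2.4-fold lower number from compound 2 to compound 4 (0.38 log units; beyond the scatter) and an at least 2.4-fold lower number from compound 1 to compound 4 (0.38 log units; beyond the scatter). Against the dimethylamino group at the same carbon, however, the ring is not separated, with a 1.7-fold lower number from compound 3 to compound 4 (0.23 log units; within the scatter), so compound 3 goes against any reading that only a ring at this carbon lifts inhibition off the limit. The two steps beyond the scatter are floors and not full sizes, because compound 1 and compound 2 are held at a limit of the assay and not at a number: the limit of > 50000 nM in this assay, at which 2 of the 4 values shown sit.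

Furan-2-yl is the only ring shown at this carbon, so the series does not tell whether the result belongs to that ring in particular or would carry over to phenyl, thiophen-2-yl or a saturated ring such as morpholine. As far as these compounds go, how a primary amine or a longer alkyl chain such as butyl would read at the same place also stays open, as does how far the size of the group enters beyond these four compounds.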